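From 4-fluorophenyl to thiophen-2-yl at the assay limit

The compounds below may be only part of what the source reports. "The series", "measured", "known", "first", "only" and "open" are said of these compounds alone.

Compound 1 `CC(C)C(=O)OC1CCC(CN2CCN(c3cc(=O)c4cc(C(F)(F)F)cc([N+](=O)[O-])c4s3)CC2)CC1`, compound 2 `O=c1cc(N2CCN(CC3CCC(OS(=O)(=O)c4ccc5c(c4)CCO5)CC3)CC2)sc2c([N+](=O)[O-])cc(C(F)(F)F)cc12` and compound 3 `O=C(OC1CCC(CN2CCN(c3cc(=O)c4cc(C(F)(F)F)cc([N+](=O)[O-])c4s3)CC2)CC1)c1ccc(F)cc1` share one core and differ only in the group on an oxygen on a saturated carbon. In an ADME assay on Vero cells (Chlorocebus sabaeus) for cytotoxicity, read by MTT assay, with a stated time of 48 h (on this read-out lower numbers stand for stronger inhibition and higher numbers for weaker inhibition), compound 3 gives > 64 ug/mL, which is a limit and not a number. Compound 1 gives > 64 ug/mL, also a limit. Compound 2 gives > 64 ug/mL, again a limit. Compound 3 therefore stands with the other two, as the limit of > 64 ug/mL in this assay, at which 3 of the 3 values shown sit, shows.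

Compound 4 `O=C(OC1CCC(CN2CCN(c3cc(=O)c4cc(C(F)(F)F)cc([N+](=O)[O-])c4s3)CC2)CC1)c1cccs1` changes one group on a carbonyl carbon: thiophen-2-yl in place of 4-fluorophenyl on a carbonyl carbon. Going by the values given here, the closest precedent is a step that the two limits leave unreadable from compound 1 to compound 3, which has 4-fluorophenyl in place of isopropyl at that same place. The other two precedents are a step that the two limits leave unreadable from compound 1 to compound 2 and a step that the two limits leave unreadable from compound 2 to compound 3. None of them has a readable size, so no direction can be drawn from them. What is expected is a number no higher from compound 3 to compound 4 (the limit leaves the size open), with no change beyond the scatter. The estimate for compound 4 is 64 ug/mL, expected to lie between 32 ug/mL and 128 ug/mL. In this assay the result is expected to be a limit once more.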

Compound 4, half-maximal inhibitory concentration: > 64 ug/mL
Compound 4: a limit, no number; the forecaster's own chance of this, stated with the estimate: 85%; the middle value sits exactly at the limit.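

In this assay compound 4 gives > 64 ug/mL, which is a limit and not a number. No step from compound 1, compound 2 or compound 3 to compound 4 can be read, as all four compounds share one limit: the limit of > 64 ug/mL in this assay, at which 4 of the 4 values shown sit.

The compounds shown leave open where the true value of each lies, and whether exchanging these groups changes the read-out at all.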